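The source may report more compounds than this note shows. Statements on the series, on what has been measured and on what is new or still open speak of the compounds shown alone.

Working notes on the series built on the shared core of compound 2 `Cc1cn([C@@H]2O[C@H](CO[Si](C)(C)C(C)(C)C)[C@@]3(OS(=O)(=O)C=C3NC(N)=O)[C@H]2O[Si](C)(C)C(C)(C)C)c(=O)n(C)c1=O`, assessed in a functional assay on MT4 cells (Homo sapiens); a higher number here means that more compound is tolerated, a lower number that less compound is tolerated. Compound 1 `Cc1cn([C@@H]2O[C@H](CO[Si](C)(C)C(C)(C)C)[C@@]3(OS(=O)(=O)C=C3NCCC(=O)OCc3ccccc3)[C@H]2O[Si](C)(C)C(C)(C)C)c(=O)n(C)c1=O` reaches only a limit in this assay, > 250000 nM. Compound 2 gives 3700 nM, the highest of the two actual numbers, and compound 3 `C=C(C)C(=O)NC(=O)NC1=CS(=O)(=O)O[C@@]12[C@@H](CO[Si](C)(C)C(C)(C)C)O[C@@H](n1cc(C)c(=O)n(C)c1=O)[C@@H]2O[Si](C)(C)C(C)(C)C` gives 1190 nM. Among the measured compounds shown here, the steps that bear on the question: an at least 67-fold lower number from compound 1 to compound 2 (1.82 log units; beyond the scatter), and a 3.1-fold lower number from compound 2 to compound 3 (0.49 log units; beyond the scatter). Compound 4 `CC(=O)NC1=CS(=O)(=O)O[C@@]12[C@@H](CO[Si](C)(C)C(C)(C)C)O[C@@H](n1cc(C)c(=O)n(C)c1=O)[C@@H]2O[Si](C)(C)C(C)(C)C` is not yet measured; against compound 2 the difference is methyl in place of amino on a carbonyl carbon. For the measured compounds named here, no measured step exchanges amino for methyl on a carbonyl carbon, so only the modest step from compound 2 to compound 3 serves as a yardstick. A modest step, direction uncertain, is therefore expected, and a 1.5-fold lower number from compound 2 to compound 4 (0.17 log units; within the scatter) is the estimate. Compound 4 is expected to give 2500 nM, within 800 nM to 8000 nM.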

Compound 4, half-maximal cytotoxic concentration: 10700 nM
Estimate against measurement, compound 4: 4.3-fold (0.63 log units) below; the measured number lies above the stated range.
By their numbers in this assay, from the lowest: compound 3; then compound 2; then compound 4. At a limit, above all of these: compound 1.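

Methyl in place of amino on a carbonyl carbon gives a 2.9-fold higher number from compound 2 to compound 4 (0.46 log units; beyond the scatter), a rise that no earlier step in the series showed. The acetamido group also stands well clear of the acylated ureido group, with a 9.0-fold higher number from compound 3 to compound 4 (0.95 log units; beyond the scatter). The step from the 2-(benzyloxycarbonyl)ethyl amine is only a bound, an at least 23-fold lower number from compound 1 to compound 4 (1.36 log units; beyond the scatter), since that end of it is a limit: the limit of > 250000 nM in this assay, at which 1 of the 4 values shown sits.

Open, on these data alone, is whether the rise is particular to acetyl or extends to longer acyl chains. A propionyl or methoxycarbonyl group on the same nitrogen would test this.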